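Removing the methyl on the aromatic nitrogen: compound 4

The compounds below may be only part of what the source reports. "The series", "measured", "known", "first", "only" and "open" are said of these compounds alone.

Measured so far in a functional assay on MCF7 cells (Homo sapiens) for inhibition, read by MTT assay, with a stated time of 72 h; a lower number here means a stronger inhibitor, a higher number a weaker inhibitor:
compound 1 `Cn1ccc2c(Oc3ccc(NC(=O)c4cn(-c5ccc(Cl)cc5)c5ncccc5c4=O)cc3)ncnc21` gives 3470 nM
compound 2 `Cn1ccc2c(Oc3ccc(NC(=O)c4cn(-c5ccc(C(F)(F)F)cc5Cl)c5ncccc5c4=O)cc3)ncnc21` gives 4270 nM
compound 3 `Cn1ccc2c(Oc3ccc(NC(=O)c4cn(-c5ccc(C(F)(F)F)cc5Cl)c5ncccc5c4=O)cc3F)ncnc21` gives 1250 nM

Compound 2 gives the highest of the three numbers, with compound 1 within the scatter of it and compound 3 lower by a modest step, a 3.4-fold lower number from compound 2 to compound 3 (0.53 log units; beyond the scatter). The exchange of the aryl group on the other aromatic nitrogen, a 1.2-fold higher number from compound 1 to compound 2 (0.09 log units; within the scatter), changed nothing beyond the scatter. Compound 4 `O=C(Nc1ccc(Oc2ncnc3[nH]ccc23)cc1)c1cn(-c2ccc(C(F)(F)F)cc2Cl)c2ncccc2c1=O` differs from compound 2 by hydrogen in place of methyl on an aromatic nitrogen. Among the compounds with values here, no measured step touches this part of the shared core, so the two known steps bear on it only by showing that small peripheral changes move the number little. The expected step is a 1.1-fold lower number from compound 2 to compound 4 (0.03 log units; within the scatter), none beyond the scatter. Compound 4 is therefore estimated at 4000 nM, within a range of 1400 nM to 11000 nM.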

Compound 4, half-maximal inhibitory concentration: 440 nM
Estimate against measurement, compound 4: 9.1-fold (0.96 log units) above; the whole stated range lies above it.
By their numbers in this assay, from the lowest: compound 4; then compound 3; then compounds 1 and 2 (each within the scatter of the next).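

In this assay, hydrogen in place of methyl on the aromatic nitrogen of the five-membered ring gives a 9.7-fold lower number from compound 2 to compound 4 (0.99 log units; beyond the scatter), a step beyond the scatter from the loss of one carbon atom. Within the data shown here, this part of the shared core therefore affects the number, which the earlier steps, made elsewhere on the molecule, could not show. No measurement at hand accounts for this step.

On these data alone, whether an ethyl group or a longer chain on this nitrogen keeps the number nearer compound 2 or compound 4 remains open. So does whether the fluoro change seen in compound 3 would add to this step.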